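Swapping the halogenated benzyl for a phenylpropyl chain

A few compounds are considered here, and "the series" means these few. Any claim that something is new, unique, unknown or untested is made for them only; others in the source may bear on it.

Among the measured compounds shown here, the three compounds measured so far share one core and differ only in the group hung from the sulfur. In a functional assay on BGC-823 cells (Homo sapiens) for inhibition, read by MTT assay, with a stated time of 72 h (a higher number here means a weaker inhibitor, a lower number a stronger inhibitor), compound 2 `C=CCSc1nc2nc(C)cc(N3CC[C@@H](C)[C@@H](N(C)c4ncnc5[nH]ccc45)C3)n2n1` gives 40900 nM. Compound 3 `Cc1cc(N2CC[C@@H](C)[C@@H](N(C)c3ncnc4[nH]ccc34)C2)n2nc(SCc3ccc(F)c(Cl)c3)nc2n1` gives 98900 nM in this assay, which is the highest of the two numbers reported, with compound 2 the nearer of the pair. Compound 1 `Cc1nc2nc(SCc3ccc(Cl)cc3)nn2c(N2CC[C@@H](C)[C@@H](N(C)c3ncnc4[nH]ccc34)C2)c1C` reaches only the limit > 100000 nM in this assay, so it carries no number of its own, and one of the three values therefore sits at this limit (the limit of > 100000 nM in this assay, at which 1 of the 3 values shown sits).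

Compound 4 `Cc1cc(N2CC[C@@H](C)[C@@H](N(C)c3ncnc4[nH]ccc34)C2)n2nc(SCCCc3ccccc3)nc2n1` has not yet been measured. It differs from compound 3 by phenethyl in place of 3-chloro-4-fluorophenyl on a saturated chain carbon bound to a sulfur. For the measured compounds named here, the one measured step that bears on the sulfur substituent is a 2.4-fold higher number from compound 2 to compound 3 (0.38 log units; beyond the scatter), a modest move that went beyond the scatter. Going by the values given here, with only this single step as a guide, and the change from compound 3 to compound 4 keeping a single aromatic ring while lengthening the chain and dropping both halogens, no move beyond the scatter is expected in this assay, though a limit is a real possibility given where compound 3 stands. Compound 4 is therefore estimated at 90000 nM in this assay, within 40000 nM to 200000 nM, a step from compound 3 to compound 4 of a 1.1-fold lower number from compound 3 to compound 4 (0.04 log units; within the scatter) expected.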

Compound 4, half-maximal inhibitory concentration: > 100000 nM
Compound 4 was reported as a limit; the forecaster's own chance of this, stated with the estimate: 45%; middle value at least 1.1-fold (0.04 log units) from the limit.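

Compound 4 is reported in this assay only as a limit, and it is one of two compounds that stand there: the limit of > 100000 nM in this assay, at which 2 of the 4 values shown sit. The result is a number no lower from compound 3 to compound 4 (the limit leaves the size open) and so the data show only that replacing 3-chloro-4-fluorobenzyl with 3-phenylpropyl on the sulfur, which removes both halogens and lengthens the chain, does not yield a lower number. Relative to the vinyl-bearing chain of compound 2, the result is an at least 2.4-fold higher number from compound 2 to compound 4 (0.38 log units; beyond the scatter), which matches a 2.4-fold higher number from compound 2 to compound 3 (0.38 log units; beyond the scatter); among these three compounds, which differ only in the group on the sulfur, both groups carrying a phenyl ring therefore give a weaker result than the one without, and none of the three goes against this.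

On these data alone, how far compound 4 lies from compound 3 remains open, as the limit hides any gap between them. Also open, as far as these compounds go, is how a shorter chain such as methyl, or a chain ending in an amine or a carboxylic acid, would read in this assay.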